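A few compounds are considered here, and "the series" means these few. Any claim that something is new, unique, unknown or untested is made for them only; others in the source may bear on it.

Measured so far:
Compound 1 `CC1(OC(=O)N2CC3COCC(C2)C3Oc2ncnc(Nc3ccc(F)cc3F)c2F)CC1` gives 44 nM in a functional assay for agonist activity at Glucose-dependent insulinotropic receptor (Mus musculus), read by cAMP accumulation; on this read-out lower numbers stand for an effect already at smaller amounts and higher numbers for an effect only at larger amounts of compound.
Compound 2 `N#Cc1ccc(Oc2ncnc(OC3C4COCC3CN(c3ncc(F)cn3)C4)c2C2CC2)c(Cl)c1` gives 248 nM in this assay.

Compound 1 holds the lowest of the two numbers; the number of compound 2 lies well above it, a gap beyond the usual scatter. Compound 2 differs from compound 1 in several places at once, so the two values stand side by side without a single step connecting them.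

Compound 3 `CC1(OC(=O)N2CC3COCC(C2)C3Oc2ncnc(Nc3cccnc3Cl)c2F)CC1` keeps the core of compound 1 and differs in one place: 2-chloropyridin-3-yl in place of 2,4-difluorophenyl on a nitrogen on an aromatic ring. Within the data shown here, no measured pair shows this exchange, so the size of its step in this assay can only be estimated. An exchange of one six-membered aromatic ring for another on a nitrogen on an aromatic ring, with the rest of compound 1 unchanged, is expected to shift the number by a modest amount, more likely toward higher values than lower. The expected step is a 1.5-fold higher number from compound 1 to compound 3 (0.17 log units; within the scatter), which may not clearly exceed the scatter. For compound 3 the estimate in this assay is 65 nM, with a range from 20 nM to 220 nM.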

Compound 3, half-maximal effective concentration: 58 nM
Estimate against measurement, compound 3: 1.1-fold (0.05 log units) above; the range from low to high includes it.
By their numbers in this assay, from the lowest: compounds 1 and 3 (each within the scatter of the next); then compound 2.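

In this assay, among these compounds, the exchange of 2,4-difluorophenyl for 2-chloropyridin-3-yl on a nitrogen on an aromatic ring is the first single-place step, and it reads a 1.3-fold higher number from compound 1 to compound 3 (0.12 log units; within the scatter) with no shift beyond the scatter. At this place, then, the shared core accepts a six-membered aromatic ring with a hetero atom and a chlorine in place of a carbon-only ring with two fluorines, although the entering group carries a hydrogen-bond acceptor that the leaving group lacks. No measurement at hand accounts for this outcome.

The step changes the ring atom and the halogens together, so the share of the pyridine nitrogen and that of the chlorine cannot be separated, and compound 2 differs from compound 1 in too many places to help. Also open, as far as these compounds go, is how far this place stays permissive beyond these two aromatic rings, for example with an unsubstituted pyridin-3-yl, a cyclohexyl group or a longer alkyl chain on the same nitrogen.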